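The source may report more compounds than this note shows. Statements on the series, on what has been measured and on what is new or still open speak of the compounds shown alone.

In an ADME assay on microsomes from liver (Rattus norvegicus) for metabolic stability, read by LC-MS, using NADPH, with a stated time of 30 min, tested at 0.1 uM, in the presence of a further agent that is not named here (a lower number here means that less of the compound is left, a higher number that more of the compound is left), compound 1 `Nc1ncc(-c2ccc(C(=O)N3CCC(O)C3)cc2)nc1-c1ccc(C(F)(F)F)cc1` gives > 90%, which is a limit of the assay and not a number. Compound 2 `N#Cc1ccc(-c2cnc(N)c(-c3ccc(N)nc3)n2)cc1` gives > 90%, which is also a limit. The measurements so far therefore amount to the limit of > 90% in this assay, at which 2 of the 2 values shown sit, and compound 1 has no exact place on the scale. Compound 3 `Nc1ncc(-c2ccc(C(=O)O)cc2)nc1-c1ccc(C(F)(F)F)cc1` keeps the core of compound 1 but carries hydroxy in place of 3-hydroxypyrrolidin-1-yl on a carbonyl carbon, so that (3-hydroxypyrrolidin-1-yl)carbonyl becomes carboxy: hydroxy in place of 3-hydroxypyrrolidin-1-yl on a carbonyl carbon. Going by the values given here, no pair of measured compounds shows what a change of this kind does in this assay. The expected step, a step that the limit leaves unreadable from compound 1 to compound 3, is none beyond the usual scatter, and no direction is expected. Compound 3 is estimated at 92%, with an expected range from 75% to 100%.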

Compound 3, percent of the compound remaining: > 90%
Compound 3: a limit, no number; the forecaster's own chance of this, stated with the estimate: 55%; the middle value lies beyond the limit too.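

In this assay compound 3 gives > 90%, which is a limit and not a number; compound 1 also stands at a limit, so no step can be read between compound 1 and compound 3. The compounds shown leave open what hydroxy in place of 3-hydroxypyrrolidin-1-yl does to the percent of compound remaining: the limit of > 90% in this assay, at which 3 of the 3 values shown sit.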